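Aromatic substituent swaps in a growth-inhibition series

This account rests on a few compounds, and the source may have more. Where it says the series, first, only, none or still open, it means among the compounds named here.

Measured compounds:
Compound 1 `COC(=O)[C@@]1(C)CC[C@@H]2C3=C1CC[C@@H](C)[C@]3(C)C[C@@H]1c3ccccc3N[C@H]21` in a functional assay on SW1573 cells (Homo sapiens) for inhibition, read by sulforhodamine B assay, with a stated time of 48 h; a higher number here means a weaker inhibitor of growth, a lower number a stronger inhibitor of growth: 30000 nM
Compound 2 `COC(=O)[C@@]1(C)CC[C@@H]2C3=C1CC[C@@H](C)[C@]3(C)C[C@@H]1c3cc(C)ccc3N[C@H]21` in this assay: 23000 nM
Compound 3 `COC(=O)[C@@]1(C)CC[C@@H]2C3=C1CC[C@@H](C)[C@]3(C)C[C@@H]1c3cc(F)ccc3N[C@H]21` in this assay: 27000 nM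

On these three numbers compound 3 stands second highest; its nearest neighbour is compound 1 and the furthest is compound 2, and both gaps are within the scatter, so no order among the three can be read. Going by the values given here, the steps that bear on the next change are a 1.1-fold lower number from compound 1 to compound 3 (0.05 log units; within the scatter) and a 1.2-fold higher number from compound 2 to compound 3 (0.07 log units; within the scatter), with a 1.3-fold lower number from compound 1 to compound 2 (0.12 log units; within the scatter) as the third, and each of them is within the scatter.

Compound 4 `COC(=O)[C@@]1(C)CC[C@@H]2C3=C1CC[C@@H](C)[C@]3(C)C[C@@H]1c3cc(OC)ccc3N[C@H]21` is not yet measured. It differs from compound 3 by methoxy in place of fluoro on an aromatic carbon. Every aromatic substituent change seen so far has left this assay unmoved beyond the scatter, so for this step too no change beyond the scatter is expected in either direction. Compound 4 is therefore estimated to give 27000 nM, with a range from 12000 nM to 60000 nM, which corresponds to an expected step of no change at the digits printed from compound 3 to compound 4 (within the scatter).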

Compound 4, concentration for 50% growth inhibition: 25000 nM
Compound 4: the middle estimate sits 1.1-fold (0.03 log units) above what was measured; low and high end bracket the measured number.
By their numbers in this assay, from the lowest: compounds 2, 4, 3 and 1 (each within the scatter of the next).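

In this assay, methoxy on this aromatic carbon gives a 1.1-fold lower number from compound 3 to compound 4 (0.03 log units; within the scatter), a 1.1-fold higher number from compound 2 to compound 4 (0.04 log units; within the scatter) and a 1.2-fold lower number from compound 1 to compound 4 (0.08 log units; within the scatter). Going by these compounds alone, the series now extends to a group with two heavy atoms and one hydrogen-bond acceptor, in place of fluoro with one heavy atom and none, and still no step at this position leaves the scatter, so the four compounds cannot be ordered. No separate measurement is available to explain this flat result.

Still open, going by these compounds, is whether an amine, a carboxylic acid or a longer chain such as butoxy on this aromatic carbon would shift the number beyond the scatter. Also open, on these data alone, is whether a change elsewhere on the shared core, such as an amide in place of the methyl ester, would do so.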